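The source may report more compounds than this note shows. Statements on the series, on what has been measured and on what is new or still open speak of the compounds shown alone.

Measured in a physicochemical assay for pharmacokinetics; a higher number here means that the compound lasts longer, a lower number that the compound disappears faster:
Compound 1 `CC(NC(=O)N1C(=O)c2ccccc2S1(=O)=O)c1ccccc1`: > 166 h, a limit
Compound 2 `COc1cccc(CNC(=O)N2C(=O)c3ccccc3S2(=O)=O)c1`: > 166 h, a limit
Compound 3 `O=C(c1ccccc1)N1C(=O)c2ccccc2S1(=O)=O`: > 0.875 h, a limit

Among the compounds with values here, none of the three compounds has an exact half-life, so no step between them can be given a size. Compound 2 stands at the limit of > 166 h in this assay, at which 2 of the 3 values shown sit. Within the data shown here, compound 1 is the only other compound there. Compound 3 stands apart, at the limit of > 0.875 h in this assay, at which 1 of the 3 values shown sits.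

The next compound is compound 4 `Cc1ccccc1CNC(=O)N1C(=O)c2ccccc2S1(=O)=O`, whose half-life has not yet been measured. It keeps the shared core of compound 2 and carries 2-methylphenyl in place of 3-methoxyphenyl on a saturated chain carbon bound to an amide-type nitrogen. The swap leaves the aromatic ring of carbon only in place and removes the one hydrogen-bond acceptor that the leaving group counts.

Among the measured compounds shown here, no measured pair shows what such a swap does, so the expectation is modest. In this assay, no step beyond the usual scatter is expected in either direction. This expectation rests on compound 2, with its limit of > 166 h. The estimate is a step that the limit leaves unreadable from compound 2 to compound 4, which is expected to stay within that scatter. The result may well be reported only as a limit again. For compound 4 the expected half-life is 180 h, with an estimated range from 90 h to 360 h.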

Compound 4, half-life: > 166 h
Compound 4: only a limit was reported (the forecaster's own chance of this, stated with the estimate: 80%); the middle value is on the limit's open side.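

In this assay, within the data shown here, compound 4 gives > 166 h, a limit, and compound 2 also has only a limit, so no step between the two can be read. Compound 4 stands with compound 1 and compound 2: the limit of > 166 h in this assay, at which 3 of the 4 values shown sit.

The compounds shown leave open what exact half-lives these three compounds have, and whether 2-methylphenyl in place of 3-methoxyphenyl changes the half-life at all.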